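The source may report more compounds than this note shows. Statements on the series, on what has been measured and on what is new or still open speak of the compounds shown alone.

Of the compounds shown here, two have been measured in a functional assay on HEK293 cells for positive allosteric modulation of metabotropic glutamate receptor 5 (Homo sapiens), read by FLIPR and calcium flux; a higher number here means that more compound is needed for the effect, a lower number that less compound is needed. Compound 1 `O=C(COCc1ccccc1)N1CCN(c2ccccc2Cl)CC1` gives 1100 nM in this assay. Compound 2 `O=C(COCc1ccccc1)N1CCN(c2ccc(Cl)cc2Cl)CC1` gives 1000 nM in this assay. Within the data shown here, the single step between them, a 1.1-fold lower number from compound 1 to compound 2 (0.04 log units; within the scatter), leaves the number effectively unchanged. Compound 2 thus holds the lower of the two numbers, but compound 1 lies within the scatter of it, so no order between the two can be claimed.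

Compound 3 `O=C(COCc1ccccc1)N1CCN(c2ccc(F)cc2F)CC1` is the next compound for this assay. It differs from compound 2 by 2,4-difluorophenyl in place of 2,4-dichlorophenyl on an amine nitrogen in a ring. Among the measured compounds shown here, no measured step bears directly on this exchange: the one step in hand, a 1.1-fold lower number from compound 1 to compound 2 (0.04 log units; within the scatter), adds chloro in place of hydrogen on an aromatic carbon rather than exchanging one halogen for another, and it stayed within the scatter. For the measured compounds named here, the series so far gives no sign that changes on this aryl group move the number far, and nothing in hand argues for a large step in either direction. For compound 3 the expected value in this assay is therefore 1500 nM, with a range from 500 nM to 4500 nM. This expectation corresponds to a 1.5-fold higher number from compound 2 to compound 3 (0.18 log units; within the scatter), a step expected to stay near the scatter.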

Compound 3, half-maximal effective concentration: 300 nM
For compound 3 the middle estimate is 5.0-fold (0.70 log units) above the measured one; the measured number lies below the stated range.
By their numbers in this assay, from the lowest: compound 3; then compounds 2 and 1 (each within the scatter of the next).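

Among these compounds, on the aryl group at the amine nitrogen of the ring, the halogen itself now matters in this assay: 2,4-difluorophenyl in place of 2,4-dichlorophenyl gives a 3.3-fold lower number from compound 2 to compound 3 (0.52 log units; beyond the scatter), the first exchange to pass beyond the scatter. The comparison with the 2-chlorophenyl of compound 1 points the same way, with a 3.7-fold lower number from compound 1 to compound 3 (0.56 log units; beyond the scatter), whereas the added chloro alone gave only a 1.1-fold lower number from compound 1 to compound 2 (0.04 log units; within the scatter), so this aryl group is less indifferent to change than that earlier step suggested. Nothing in hand gives a reason for the gain seen with the two fluoro groups.

The three compounds leave open whether both fluoro groups are needed for this step, and how a monofluorophenyl, an unsubstituted phenyl or a methoxyphenyl on the same nitrogen would read. As far as these compounds go, all three also share the rest of the core, so the response to a longer chain or an amine elsewhere in the molecule remains unknown, as does whether the fluoro gain would carry over to such changes.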